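This account rests on a few compounds, and the source may have more. Where it says the series, first, only, none or still open, it means among the compounds named here.

Measured so far in an ADME assay on Vero cells (Chlorocebus sabaeus) for cytotoxicity, read by CellTiter-Glo, with a stated time of 72 h; on this read-out lower numbers stand for higher toxicity in this test and higher numbers for lower toxicity in this test:
- compound 1 `[O-][n+]1nc(NC2CC2)[n+]([O-])c2ccc(F)cc21`: 1.3 ug/mL
- compound 2 `COCC(C)Nc1n[n+]([O-])c2cc(F)ccc2[n+]1[O-]`: 6.3 ug/mL
- compound 3 `[O-][n+]1nc(N[C@@H]2C[C@H]3CC[C@@H]2C3)[n+]([O-])c2ccc(F)cc21`: < 2.5 ug/mL

Compound 3 is known only through a limit, < 2.5 ug/mL, and not through a number.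

Compound 4 `COc1ccc2c(c1)[n+]([O-])nc(N[C@@H]1C[C@H]3CC[C@@H]1C3)[n+]2[O-]` keeps the group on nitrogen of compound 3 and carries methoxy in place of fluoro on an aromatic carbon. The measured steps all change the group on nitrogen: a 4.8-fold higher number from compound 1 to compound 2 (0.69 log units; beyond the scatter), an at least 2.5-fold lower number from compound 2 to compound 3 (0.40 log units; beyond the scatter) and a step that the limit leaves unreadable from compound 1 to compound 3. None of them tests the fluoro, so they give only weak guidance, and no step beyond the scatter is expected in this assay. The estimated move is a step that the limit leaves unreadable from compound 3 to compound 4. Compound 4 is expected at 1.8 ug/mL, within 0.6 ug/mL to 5 ug/mL.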

Compound 4, half-maximal cytotoxic concentration: > 50 ug/mL
Compound 4: no number, only a limit; the forecaster's own chance of this, stated with the estimate: 35%; middle value at least 27-fold (1.44 log units) from the limit.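

In this assay, among these compounds, methoxy in place of fluoro on an aromatic carbon, with the group on nitrogen held, gives an at least 20-fold higher number from compound 3 to compound 4 (1.30 log units; beyond the scatter), so this position also moves the read-out, which the earlier steps on nitrogen could not show. Compound 3 is known only through a limit: the limit of < 2.5 ug/mL in this assay, at which 1 of the 4 values shown sits. Compound 4 is likewise known only through a limit: the limit of > 50 ug/mL in this assay, at which 1 of the 4 values shown sits.

On these data alone, whether methoxy gives such a step with cyclopropyl or 1-(methoxymethyl)ethyl on nitrogen stays open. Also open, as far as these compounds go, is how an amine or a carboxylic acid on this aromatic carbon would read.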